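From Bromo to Chloro: A Question of Cell Toxicity

This account rests on a few compounds, and the source may have more. Where it says the series, first, only, none or still open, it means among the compounds named here.

In an ADME assay on J774 cells (Mus musculus) for cytotoxicity (on this read-out lower numbers stand for an effect already at smaller amounts and higher numbers for an effect only at larger amounts of compound), compound 1 `CCCCc1cc2c(=O)c(I)c(C)[nH]c2cc1OCCOc1ccccc1` has no single number, and its entry reads "not determined" (no result reported) in the record. In this assay compound 2 `CCCCc1cc2c(=O)c(Br)c(C)[nH]c2cc1OCCOc1ccccc1` stands at > 10000 nM as a limit of the assay and not a number. So far, then, neither compound offers an exact value to work from.

Compound 3 `CCCCc1cc2c(=O)c(Cl)c(C)[nH]c2cc1OCCOc1ccccc1` has not yet been measured. Compared with compound 2, it has chloro in place of bromo on an aromatic carbon. Among the measured compounds shown here, no measured step between two compounds is available to guide this swap, so in this assay no change beyond the usual scatter is expected, in either direction. That expectation rests on compound 2 and its limit (> 10000 nM), and compound 3 is expected to end at such a limit as well. The expected size of the change is a step that the limit leaves unreadable from compound 2 to compound 3 in this estimate. For compound 3 the estimated value is 15000 nM with an expected range from 6000 nM to 40000 nM in this measurement.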

Compound 3, half-maximal effective concentration: > 10000 nM
Compound 3: a limit, no number (the forecaster's own chance of this, stated with the estimate: 85%); the middle value is on the limit's open side.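

Compound 2 and compound 3 both end at a limit of this assay rather than a number, so no step can be read between them: the limit of > 10000 nM in this assay, at which 2 of the 3 values shown sit.

The compounds shown leave open whether chloro in place of bromo on this aromatic carbon changes cytotoxicity at all, and at what amount either compound would have an effect.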